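Trading a biaryl for a bromine on the legumain inhibitor core

This account rests on a few compounds, and the source may have more. Where it says the series, first, only, none or still open, it means among the compounds named here.

Compound 1 `CC(C(=O)N[C@H](C#N)CC(N)=O)N(Cc1ccc(-c2cccc(Cl)c2)cc1)S(C)(=O)=O` shows 425 nM in an assay on isolated protein for inhibition of legumain (Homo sapiens), with stated times of 2 min and 60 min (a higher number here means a weaker inhibitor, a lower number a stronger inhibitor), the lower of the two numbers in hand; compound 2 `CC(C)CS(=O)(=O)N(Cc1ccc(-c2cccc(F)c2F)cc1)[C@@H](C)C(=O)N[C@H](C#N)CC(N)=O` gives 1820 nM in this assay, a higher number that lies beyond the usual scatter. Compound 3 `CC(C(=O)N[C@H](C#N)CC(N)=O)N(Cc1ccc(Br)cc1)S(C)(=O)=O` has not been measured; it differs from compound 1 by bromo in place of 3-chlorophenyl on an aromatic carbon. Going by the values given here, with no measured step of this kind to lean on, a moderate weakening is expected, a 2.6-fold higher number from compound 1 to compound 3 (0.41 log units; beyond the scatter). Compound 3 is therefore estimated at 1100 nM, within a range from 300 nM to 4000 nM.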

Compound 3, half-maximal inhibitory concentration: > 10000 nM
Compound 3 ended at the assay's limit; the forecaster's own chance of this, stated with the estimate: 5%; middle value at least 9.0-fold (0.95 log units) away from the limit.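

Going by these compounds alone, on the shared core, the aromatic carbon para to a large group tolerates this change poorly: putting bromo in place of 3-chlorophenyl gives an at least 23-fold higher number from compound 1 to compound 3 (1.37 log units; beyond the scatter), a large loss of inhibition that the earlier compounds could not reveal. The value of compound 3 in this assay is a limit and not a number, so this step has no upper bound: the limit of > 10000 nM in this assay, at which 1 of the 3 values shown sits.

The compounds shown leave open whether the outer ring alone or its chlorine matters. A plain phenyl or a pyridine ring at this carbon would separate those two contributions.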